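The source may report more compounds than this note shows. Statements on the series, on what has been measured and on what is new or still open speak of the compounds shown alone.

Among the measured compounds shown here, only two compounds sharing one core have been measured so far in a functional assay on MGC-803 cells (Homo sapiens) for antiproliferative activity, read by MTT assay, with a stated time of 72 h; on this read-out lower numbers stand for stronger inhibition and higher numbers for weaker inhibition. In that test compound 1 `CCCSc1nc(N/N=C(\C)c2ccccc2O)c2nnn(Cc3ccccc3)c2n1` gives 2310 nM, while compound 2 `CCCSc1nc(N/N=C/c2ccc(Br)cc2)c2nnn(Cc3ccccc3)c2n1` gives 34900 nM, the higher of the two numbers and so the weaker inhibition of the pair. Compound 3 `CCCSc1nc(N/N=C/c2ccccc2F)c2nnn(Cc3ccccc3)c2n1` differs from compound 2 at a single place: 2-fluorophenyl in place of 4-bromophenyl on a carbon with a double bond to nitrogen. That place is a carbon with a double bond to nitrogen.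

For the measured compounds named here, only one measured step bears on this change, and it is large: a 15-fold higher number from compound 1 to compound 2 (1.18 log units; beyond the scatter). It replaces a bigger piece of the molecule that includes this place, so it gives only a loose guide to swapping 4-bromophenyl for 2-fluorophenyl alone. Going by the values given here, no measured compound carries 2-fluorophenyl. Compound 2 sits at the high end of the small range seen so far with 34900 nM, so a modest move towards a lower number is expected in this assay, smaller than the measured step, and a result within the scatter remains possible. The estimated change is a 2.5-fold lower number from compound 2 to compound 3 (0.40 log units; beyond the scatter). For compound 3 the expected value is 14000 nM, within an estimated range of 4000 nM to 45000 nM.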

Compound 3, half-maximal inhibitory concentration: > 64000 nM
Compound 3: only a limit was reported; the forecaster's own chance of this, stated with the estimate: 10%; middle value at least 4.5-fold (0.66 log units) away from the limit.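

In this assay compound 3 gives only a limit of the assay, not a number: the limit of > 64000 nM in this assay, at which 1 of the 3 values shown sits.

As far as these compounds go, putting 2-fluorophenyl in place of 4-bromophenyl on a carbon with a double bond to nitrogen brings no recovery of inhibition: the step is an at least 1.8-fold higher number from compound 2 to compound 3 (0.26 log units; that floor lies within the scatter), and with a floor that small, the true distance between these two compounds stays unknown and could be small or large. The comparison with the best compound here is clearer, with an at least 27-fold higher number from compound 1 to compound 3 (1.44 log units; beyond the scatter), so compound 1, with its oxygen-carrying group, remains the strongest inhibitor of the three, and neither halogen-carrying group comes close to it.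

2-Fluorophenyl and 4-bromophenyl differ both in the halogen and in where it sits on the ring, so these compounds cannot say which of the two matters, and 4-fluorophenyl or 2-bromophenyl would be needed to separate them. Also open, from the compounds shown here alone, is how a plain phenyl, or a phenyl carrying an amine, would read in this assay, and whether the oxygen or the extra methyl of compound 1 accounts for its stronger inhibition.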